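A few compounds are considered here, and "the series" means these few. Any claim that something is new, unique, unknown or untested is made for them only; others in the source may bear on it.

Measured so far:
compound 1, `CCCCCCCCCOC(=O)CCC(=O)N1CCN(CCCOc2cc3c(Nc4ccc(F)c(Cl)c4)ncnc3cc2OC)CC1`: 17.9%
compound 2, `CCCCCCCCCCOC(=O)CCC(=O)N1CCN(CCCOc2cc3c(Nc4ccc(F)c(Cl)c4)ncnc3cc2OC)CC1`: 15.5%
compound 3, `CCCCCCCCCCCCCCCCCCOC(=O)CCC(=O)N1CCN(CCCOc2cc3c(Nc4ccc(F)c(Cl)c4)ncnc3cc2OC)CC1`: 91%

All three compounds were read in a functional assay on A549 cells (Homo sapiens) for cytotoxicity, read by MTT assay, with a stated time of 24 h, tested at 40 uM; a lower number here means a stronger effect, a higher number a weaker effect of the compound at the concentration tested. Compound 1 gives 17.9% in this assay, compound 2 gives 15.5%, and compound 3 gives 91%.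

Compound 1 and compound 2 share a core and differ only by methyl in place of hydrogen on a saturated chain carbon, nine bonds along the chain from an oxygen next to a carbonyl group. That change made a step of a number 2.4 percentage points lower from compound 1 to compound 2 (within the scatter). The core of compound 3 differs from that of compound 1 by nonyl in place of hydrogen on a saturated chain carbon, nine bonds along the chain from an oxygen next to a carbonyl group, with a step of a number 73.1 percentage points higher from compound 1 to compound 3 (beyond the scatter); from compound 2 to compound 3 the step is a number 75.5 percentage points higher from compound 2 to compound 3 (beyond the scatter). Compound 3 stands highest of the three measured numbers, beyond the scatter from both others.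

Compound 4, `CCCCCCCCCCCCCCCCCCCOC(=O)CCC(=O)N1CCN(CCCOc2cc3c(Nc4ccc(F)c(Cl)c4)ncnc3cc2OC)CC1`, is not yet measured in this assay. It differs from compound 3 by methyl in place of hydrogen on a saturated chain carbon, ten or more bonds along the chain from an oxygen next to a carbonyl group. This is the same kind of change as that from compound 1 to compound 2, though not at the same place along the chain, as the two differences show.

Within the data shown here, the step from compound 3 to compound 4 in this assay is expected to be a number 1 percentage points lower from compound 3 to compound 4 (within the scatter), within the scatter, because the one measured instance of this kind of change, a number 2.4 percentage points lower from compound 1 to compound 2 (within the scatter), stayed within the scatter. The value of compound 4 is therefore estimated at 90%. For compound 4 the expected range runs from 75% to 102%.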

Compound 4, a percentage reported as activity, at one concentration (the size of the read-out at that concentration, not a potency): 92.3%
Compound 4: middle estimate off by 2.3 percentage points, on the low side; measured number inside the range.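

In this assay the methyl addition carried over from the core of compound 1 to the core of compound 3, with a step of a number 1.3 percentage points higher from compound 3 to compound 4 (within the scatter), and the two instances do not differ: the same change on two cores in this assay, a number 2.4 percentage points lower (within the scatter) from compound 1 to compound 2 and a number 1.3 percentage points higher (within the scatter) from compound 3 to compound 4, 3.7 percentage points apart, within the scatter of two such steps. The large steps also held on the longer chain, with a number 76.8 percentage points higher from compound 2 to compound 4 (beyond the scatter) and a number 74.4 percentage points higher from compound 1 to compound 4 (beyond the scatter), and the nonyl addition read alike on two cores: the same change on two cores in this assay, a number 73.1 percentage points higher (beyond the scatter) from compound 1 to compound 3 and a number 76.8 percentage points higher (beyond the scatter) from compound 2 to compound 4, 3.7 percentage points apart, within the scatter of two such steps. This shows that, in these four compounds and at the single concentration tested, the read-out follows the group of short chains or the group of long chains, and a methyl addition within either group leaves it within the scatter; it does not show that a methyl addition stays this small everywhere along the chain, and it gives no cause for the large steps.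

The compounds shown leave open where between the chains of compound 2 and compound 3 the large step occurs, which a dodecyl or a tetradecyl chain would help to place, and whether a methyl addition stays small in that stretch. Also open, going by these compounds, is whether the same carry-over holds for a chain ending in an amine or a carboxylic acid.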